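From vinyl to pentyl on a triple-bonded carbon

The compounds below may be only part of what the source reports. "The series", "measured", "known", "first", "only" and "open" are said of these compounds alone.

In an ADME assay on L1210/0 cells (Mus musculus) for cytotoxicity, with a stated time of 48 h (a lower number here means a stronger inhibitor, a higher number a weaker inhibitor), compound 1 (`CCCC/C=C\c1cn([C@H]2C[C@H](O)[C@@H](CO)O2)c(=O)[nH]c1=O`) reads > 200000 nM as a limit of the assay. Compound 2 (`C=CC#Cc1cn([C@H]2C[C@H](O)[C@@H](CO)O2)c(=O)[nH]c1=O`) reads > 200000 nM and this too is a limit, not a number. Compound 3 (`CCCCCC#Cc1cn([C@H]2C[C@H](O)[C@@H](CO)O2)c(=O)[nH]c1=O`) brings the change pentyl in place of vinyl on a triple-bonded carbon with pentyl in place of vinyl on a triple-bonded carbon. For the measured compounds named here, the one measured step is a step that the two limits leave unreadable from compound 1 to compound 2 and it gives no size to carry over. The expected a number no higher from compound 2 to compound 3 (the limit leaves the size open) in this assay is therefore no shift beyond the scatter in either direction. Compound 3 is expected at 200000 nM with an estimated range of 80000 nM to 400000 nM and may report only a limit.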

Compound 3, half-maximal inhibitory concentration: > 200000 nM
Compound 3: only a limit was reported; the forecaster's own chance of this, stated with the estimate: 70%; the middle value sits exactly at the limit.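

No step can be read among compound 1, compound 2 and compound 3, because each gives only a limit, not a number: the limit of > 200000 nM in this assay, at which 3 of the 3 values shown sit.

The compounds shown leave open whether these side chains on the shared core differ in cytotoxicity at all.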